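Removing the methyl from the aryl ether of compound 2

A few compounds are considered here, and "the series" means these few. Any claim that something is new, unique, unknown or untested is made for them only; others in the source may bear on it.

Compound 2 `COc1cc(-c2nn(-c3cccc(NC(=O)Nc4cc(C(F)(F)F)cc(C(F)(F)F)c4)c3)cc2-c2ccncc2)ccc1Cl` gives 2790 nM in a functional assay on CCRF-CEM cells (Homo sapiens) for inhibition, read by sulforhodamine B assay, with a stated time of 48 h (on this read-out higher numbers stand for weaker inhibition of growth and lower numbers for stronger inhibition of growth), the only number shown. Compound 1 `O=C(Nc1cccc(-n2cc(-c3ccncc3)c(-c3ccc(Cl)c(O)c3)n2)c1)Nc1cccc(C(F)(F)F)c1` stands at a limit, > 32500 nM in this assay, with the limit of > 32500 nM in this assay, at which 1 of the 2 values shown sits, marking the extent of its inactivity. Compound 3 `O=C(Nc1cccc(-n2cc(-c3ccncc3)c(-c3ccc(Cl)c(O)c3)n2)c1)Nc1cc(C(F)(F)F)cc(C(F)(F)F)c1` differs from compound 2 by hydrogen in place of methyl on an oxygen on an aromatic ring, methoxy to hydroxy. For the measured compounds named here, no measured step covers this change; the author expects the step from compound 2 to compound 3 to run toward weaker growth inhibition, a 3.2-fold higher number from compound 2 to compound 3 (0.51 log units; beyond the scatter), beyond the scatter. Compound 3 is estimated at 9000 nM, with a range from 2500 nM to 32500 nM.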

Compound 3, concentration for total growth inhibition: 6780 nM
Compound 3: middle estimate off by 1.3-fold (0.12 log units), on the high side; measured number inside the range.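

In this assay, methoxy to hydroxy on the aromatic ring weakens growth inhibition only modestly, with a 2.4-fold higher number from compound 2 to compound 3 (0.39 log units; beyond the scatter), so compound 3 keeps a measurable value without the methyl. With the hydroxy in place, trifluoromethyl in place of hydrogen on an aromatic carbon gives an at least 4.7-fold lower number from compound 1 to compound 3 (0.68 log units; beyond the scatter). Compound 1 stands at a limit, so that step gives a bound rather than a size: the limit of > 32500 nM in this assay, at which 1 of the 3 values shown sits.

The compounds shown leave open how an ethoxy or an amine at this place would compare. They also leave open whether methoxy to hydroxy costs as much when the other ring carries only one trifluoromethyl.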